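Repositioning the benzamide substituents in an N-type blocker series

The source may hold more compounds than are shown below. What is called first, only, known or untested is meant among the compounds shown, and "the series" means these compounds.

The series shares a piperidine amide carrying a cyclopropyl sulfonamide, and its activity is followed in an assay on HEK293 cells for inhibition of Voltage-dependent N-type calcium channel subunit alpha-1B (Homo sapiens), read by FLIPR and calcium flux; a lower number here means a stronger inhibitor, a higher number a weaker inhibitor. Compound 1 `NS(=O)(=O)c1cccc(C(F)(F)F)c1` is the bare sulfonamide fragment, and in this assay compound 1 reaches only the limit of > 10000 nM, which is a boundary of the assay rather than a number (the limit of > 10000 nM in this assay, at which 1 of the 3 values shown sits). Compound 2 `CS(=O)(=O)c1ccc(C#N)cc1C(=O)N1CCC(N(C2CC2)S(=O)(=O)c2cccc(C(F)(F)F)c2)CC1` gives 670 nM, the higher of the two numbers in hand. Compound 3 `CS(=O)(=O)c1cc(C(F)(F)F)ccc1C(=O)N1CCC(N(C2CC2)S(=O)(=O)c2cccc(C(F)(F)F)c2)CC1` gives 27 nM, a value that sits clearly below that of compound 2, beyond the usual scatter, with the trifluoromethyl of compound 3 standing where compound 2 carries a nitrile.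

Compound 4 `CS(=O)(=O)c1ccc(Cl)c(C(=O)N2CCC(N(C3CC3)S(=O)(=O)c3cccc(C(F)(F)F)c3)CC2)c1` is not yet measured. It differs from compound 2 by 2-chloro-5-(methylsulfonyl)phenyl in place of 5-cyano-2-(methylsulfonyl)phenyl on a carbonyl carbon: the methylsulfonyl changes position on the ring and a chlorine replaces the nitrile. Among the measured compounds shown here, with no measured pair that isolates this swap, the expectation leans on the gain seen for compound 3 over compound 2 when a lipophilic halogenated group replaces the nitrile. For compound 4 the estimate is a lower number than compound 2 in this assay, a step of a 4.5-fold lower number from compound 2 to compound 4 (0.65 log units; beyond the scatter), with moderate confidence. Compound 4 is therefore expected at 150 nM, in the range 30 nM to 700 nM.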

Compound 4, half-maximal inhibitory concentration: 340 nM
Compound 4: middle estimate off by 2.3-fold (0.36 log units), on the low side; the range from low to high includes it.
By their numbers in this assay, from the lowest: compound 3; then compounds 4 and 2 (each within the scatter of the next). At a limit, above all of these: compound 1.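

In this assay, replacing 5-cyano-2-(methylsulfonyl)phenyl with 2-chloro-5-(methylsulfonyl)phenyl on the carbonyl carbon gives a 2.0-fold lower number from compound 2 to compound 4 (0.29 log units; within the scatter), so the two aryl groups cannot be told apart by this read-out, although both the nitrile and the place of the methylsulfonyl differ. Among the compounds shown here, the earlier compounds showed only that this aryl group can accompany a large difference in value, whereas this pair shows that a substantial rearrangement of the ring can leave the value unresolved, and compound 3 at 27 nM still stands well apart from the printed values of this pair. Nothing available explains why this exchange leaves the two compounds so close.

For the compounds shown here, the single step changes two features together, so it remains open whether the chlorine and the moved methylsulfonyl each have little effect or have separate effects that offset one another. Also open, as far as these compounds go, is how this place would respond to a carboxylic acid, an amine or a methoxy group on the ring, and whether a chlorine with the methylsulfonyl kept as in compound 2 would stay close to compound 2 or move towards compound 3.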